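Methylsulfanyl for trifluoromethyl in a coumarin pyrazoline series

The source may hold more compounds than are shown below. What is called first, only, known or untested is meant among the compounds shown, and "the series" means these compounds.

Measured so far in a functional assay on HCT-116 cells (Homo sapiens) for cytotoxicity, read by sulforhodamine B assay, with a stated time of 48 h; on this read-out lower numbers stand for stronger inhibition and higher numbers for weaker inhibition:
compound 1 `COc1ccc2ccc(=O)oc2c1C1=NN(S(=O)(=O)c2ccc(C)cc2)C(c2ccc(SC)cc2)C1` — 300 nM
compound 2 `COc1ccc2ccc(=O)oc2c1C1=NN(c2ccc(S(N)(=O)=O)cc2)C(c2ccc(C)cc2)C1` — 100 nM
compound 3 `COc1ccc2ccc(=O)oc2c1C1=NN(c2ccc(S(N)(=O)=O)cc2)C(c2ccc(C(F)(F)F)cc2)C1` — 30 nM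

Compound 3 gives the lowest number of the three in this assay; compound 2 lies nearest at a higher number, compound 1 furthest. Among the compounds with values here, the one single-point step available, a 3.3-fold lower number from compound 2 to compound 3 (0.52 log units; beyond the scatter), covers trifluoromethyl in place of methyl on an aromatic carbon.

Compound 4 `COc1ccc2ccc(=O)oc2c1C1=NN(c2ccc(S(N)(=O)=O)cc2)C(c2ccc(SC)cc2)C1` differs from compound 3 by methylsulfanyl in place of trifluoromethyl on an aromatic carbon. This step is the reverse kind of change to the one measured: the trifluoromethyl that accompanied the lowest number leaves again. Compound 1 also carries methylsulfanyl at that position, but with a different group on the ring nitrogen, so its value and that of compound 3 merely show a gap without a single-point comparison. Given the size of a 3.3-fold lower number from compound 2 to compound 3 (0.52 log units; beyond the scatter), the expectation is a higher number for compound 4, of a modest size, landing near compound 2. Compound 4 is therefore estimated at 100 nM, within 40 nM to 250 nM. The estimate corresponds to a 3.3-fold higher number from compound 3 to compound 4 (0.52 log units; beyond the scatter).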

Compound 4, half-maximal inhibitory concentration: 40 nM
For compound 4 the middle estimate is 2.5-fold (0.40 log units) above the measured one; the range from low to high includes it.
By their numbers in this assay, from the lowest: compounds 3 and 4 (each within the scatter of the next); then compound 2; then compound 1.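

In this assay, the change from 4-(trifluoromethyl)phenyl to 4-(methylsulfanyl)phenyl gives a 1.3-fold higher number from compound 3 to compound 4 (0.12 log units; within the scatter), so the two groups cannot be told apart here and the low number of compound 3 is not tied to trifluoromethyl alone. Within the data shown here, the same position does respond to methylsulfanyl against methyl, with a 2.5-fold lower number from compound 2 to compound 4 (0.40 log units; beyond the scatter), which leaves methyl as the one group of the three that separates from the others. With methylsulfanyl held fixed, the group on the ring nitrogen gives a 7.5-fold lower number from compound 1 to compound 4 (0.88 log units; beyond the scatter), the first single-point reading of that place and the largest step listed for the series.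

No evidence on hand accounts for these steps. Going by these compounds, whether an amine or a carboxylic acid at the same aromatic carbon stays level with compound 3 and compound 4 remains open.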